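Terminal alkyne in the cytidine series: aryl stripped away

The compounds below may be only part of what the source reports. "The series", "measured", "known", "first", "only" and "open" are said of these compounds alone.

Compound 1 `CCCCCC#Cc1cn([C@@H]2O[C@H](CO)[C@@H](O)[C@H](O)[C@H]2O)c(=O)nc1N`, compound 2 `Nc1nc(=O)n([C@@H]2O[C@H](CO)[C@@H](O)[C@H](O)[C@H]2O)cc1C#Cc1ccccc1` and compound 3 `CC(C)(C)c1ccc(C#Cc2cn([C@@H]3O[C@H](CO)[C@@H](O)[C@H](O)[C@H]3O)c(=O)nc2N)cc1` share one core and differ only in the group on a triple-bonded carbon. In a functional assay on HeLa cells (Homo sapiens) for cytotoxicity, with a stated time of 72 h (a higher number here means a weaker inhibitor, a lower number a stronger inhibitor), compound 1 gives >= 250000 nM, which is a limit of the assay rather than a number (the limit of >= 250000 nM in this assay, at which 1 of the 3 values shown sits). In this assay compound 2 gives 201000 nM and compound 3 gives 140000 nM. Compound 3 holds the lowest of the two numbers shown, with compound 2 nearest, and that gap is within the scatter. Among the compounds with values here, the steps so far are an at least 1.2-fold lower number from compound 1 to compound 2 (0.09 log units; that floor lies within the scatter), an at least 1.7-fold lower number from compound 1 to compound 3 (0.25 log units; that floor lies within the scatter) and a 1.4-fold lower number from compound 2 to compound 3 (0.16 log units; within the scatter); none clears the scatter.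

Compound 4 `C#Cc1cn([C@@H]2O[C@H](CO)[C@@H](O)[C@H](O)[C@H]2O)c(=O)nc1N` is the next step: hydrogen in place of 4-(tert-butyl)phenyl on a triple-bonded carbon. The steps from compound 1 to compound 2 and to compound 3 bear on it, since a larger group on the triple-bonded carbon went with a lower number, though only by amounts within the scatter and starting from a limit. Going the other way, to bare hydrogen, a higher number for compound 4 is expected, a 1.8-fold higher number from compound 3 to compound 4 (0.25 log units; within the scatter), with a fair chance that only a limit is reported. The estimate for compound 4 in this assay is 250000 nM, between 120000 nM and 600000 nM.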

Compound 4, half-maximal inhibitory concentration: >= 250000 nM
Compound 4 gave a limit, no number; the forecaster's own chance of this, stated with the estimate: 50%; the middle value sits exactly at the limit.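

Bare hydrogen on the triple-bonded carbon, with no substituent left at all, gives an at least 1.7-fold higher number from compound 3 to compound 4 (0.25 log units; that floor lies within the scatter) and an at least 1.2-fold higher number from compound 2 to compound 4 (0.09 log units; that floor lies within the scatter), so neither floor shows the aryl groups to matter beyond the scatter. In this assay compound 4 gives >= 250000 nM, which is a limit and not a number, so among the four compounds only the phenyl and 4-(tert-butyl)phenyl members, compound 2 and compound 3, carry numbers at this position. Hydrogen and pentyl cannot be told apart, and the step between them cannot be read: the limit of >= 250000 nM in this assay, at which 2 of the 4 values shown sit.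

Going by these compounds, how far compound 4 and compound 1 lie past that limit remains open. On these data alone, it is also open whether an amine, a carboxylic acid or a chain longer than pentyl on the triple-bonded carbon would give a step beyond the scatter.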